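The compounds below may be only part of what the source reports. "The series", "measured", "known", "first", "only" and "open" are said of these compounds alone.

Compound 1 `[O-][n+]1nc(NC2CCC2)[n+]([O-])c2ccc(F)cc21`: 1.6 ug/mL
Compound 2 `[O-][n+]1nc(NC2CCCCC2)[n+]([O-])c2ccc(F)cc21`: < 2.5 ug/mL (a limit)
Compound 3 `[O-][n+]1nc(N[C@@H]2C[C@H]3CC[C@@H]2C3)[n+]([O-])c2ccc(F)cc21`: < 2.5 ug/mL (a limit)

Among the measured compounds shown here, in an ADME assay on Vero cells (Chlorocebus sabaeus) for cytotoxicity, read by CellTiter-Glo, with a stated time of 72 h (on this read-out higher numbers stand for lower toxicity in this test and lower numbers for higher toxicity in this test), compound 1 gives 1.6 ug/mL as the only true number of the three. Compound 2 and compound 3 give only a limit, and the limit of < 2.5 ug/mL in this assay, at which 2 of the 3 values shown sit, applies to both.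

Compound 4 `[O-][n+]1nc(NC2CCC2)[n+]([O-])c2ccc(Br)cc21` differs from compound 1 by bromo in place of fluoro on an aromatic carbon in one place, with bromo in place of fluoro on an aromatic carbon. The measured steps are a step that the limit leaves unreadable from compound 1 to compound 2 and a step that the limit leaves unreadable from compound 1 to compound 3 and also a step that the two limits leave unreadable from compound 2 to compound 3 in this set. All of them alter the group on the nitrogen and leave the fluoro untouched, and none has a readable size. No step beyond the usual scatter is therefore expected in this assay and no direction is favoured. The expectation rests on compound 1 with 1.6 ug/mL as its starting point. The expected outcome is a 1.1-fold lower number from compound 1 to compound 4 (0.03 log units; within the scatter) as an estimate. Compound 4 is estimated at 1.5 ug/mL with an expected range from 0.6 ug/mL to 3.5 ug/mL in this test.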

Compound 4, half-maximal cytotoxic concentration: 3.8 ug/mL
Compound 4: middle estimate off by 2.5-fold (0.40 log units), on the low side; measured number above the stated range.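

In this assay, among the compounds shown here, the halogen on the aromatic carbon proves to matter: with the cyclobutyl group on the nitrogen held fixed, bromo in place of fluoro gives a 2.4-fold higher number from compound 1 to compound 4 (0.38 log units; beyond the scatter), the first readable step in this set and one towards lower toxicity in this test. Nothing measured here accounts for this step, which rests on a single pair of compounds. The steps that alter the group on the nitrogen cannot be read, so they offer no size to set against it: the limit of < 2.5 ug/mL in this assay, at which 2 of the 4 values shown sit.

Going by these compounds, it remains open how chloro, an amine or a carboxylic acid at this position would compare with fluoro and bromo. On these data alone, it is also open whether the same exchange would give a similar step with the cyclohexyl group on the nitrogen.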